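The compounds below may be only part of what the source reports. "The series", "measured", "known", "first", "only" and "open" are said of these compounds alone.

Compound 1 `CCN1C(=O)CC[C@H]1C(=O)NCC1CCCCC1` gives < 1000 nM in an assay on isolated protein for inhibition of P2X purinoceptor 7 (Homo sapiens) (a higher number here means a weaker inhibitor, a lower number a stronger inhibitor), which is a limit of the assay rather than a number.
Compound 2 `CCN1C(=O)CC[C@H]1C(=O)NCc1ccccc1` gives < 1000 nM in this assay, again a limit.
Compound 3 `CCN1C(=O)CC[C@H]1C(=O)NCc1ccccc1Cl` gives 631 nM in this assay.

Compound 2 thus stands only at a limit; the limit of < 1000 nM in this assay, at which 2 of the 3 values shown sit, covers two of the three values, so compound 2 cannot be placed relative to compound 1 or compound 3 on the numbers shown. Compound 4 `CCN1C(=O)CC[C@H]1C(=O)NCc1cccc(Cl)c1` differs from compound 2 in one place: chloro in place of hydrogen on an aromatic carbon. The nearest measured step is a step that the limit leaves unreadable from compound 2 to compound 3, which the limit leaves unreadable; a step that the two limits leave unreadable from compound 1 to compound 2 is likewise unreadable. For the measured compounds named here, no measured step therefore fixes a size or a direction, and the step that the limit leaves unreadable from compound 2 to compound 4 is expected to stay small. Compound 4 is estimated at 500 nM, within 150 nM to 1500 nM.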

Compound 4, half-maximal inhibitory concentration: < 1000 nM
Compound 4 was reported as a limit; the forecaster's own chance of this, stated with the estimate: 20%; the middle value lies beyond the limit too.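

In this assay compound 4 gives < 1000 nM, which is a limit, as is the value of compound 2, so no step between compound 2 and compound 4 can be read: the limit of < 1000 nM in this assay, at which 3 of the 4 values shown sit.

On these data alone, whether chloro in place of hydrogen on the aromatic carbon changes the strength of compound 2 at all, and in which direction, stays open.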